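This account rests on a few compounds, and the source may have more. Where it says the series, first, only, none or still open, it means among the compounds named here.

Measured so far in an ADME assay on microsomes (Mus musculus) for metabolic stability; a higher number here means faster removal of the compound, a lower number slower removal:
- compound 1 `Cc1cc(C(F)(F)F)c2cccc(OCc3c(Cl)ccc(S(=O)(=O)N4CCC[C@H]4CO)c3Cl)c2n1`: 1630 mL/min/kg
- compound 2 `Cc1cc(C(F)(F)F)c2cccc(OCc3c(Cl)ccc(S(=O)(=O)N4CC[C@@H](N(C)C)C4)c3Cl)c2n1`: 867 mL/min/kg

Compound 2, at 867 mL/min/kg, has the lower of the two numbers, but it cannot be separated from compound 1: the measured step is a 1.9-fold lower number from compound 1 to compound 2 (0.27 log units; within the scatter). For the measured compounds named here, both values are high, and the series has no measured compound with a clearly different number in this assay.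

The next compound is compound 3 `Cc1cc(C(F)(F)F)c2cccc(OCc3c(Cl)ccc(S(=O)(=O)N4CCCCC4)c3Cl)c2n1`, with piperidin-1-yl in place of 3-(dimethylamino)pyrrolidin-1-yl on a sulfonyl sulfur. Going by the values given here, only one measured step bears on this change: a 1.9-fold lower number from compound 1 to compound 2 (0.27 log units; within the scatter). It also exchanges the group on the sulfonyl sulfur and leaves the rest of the structure untouched. Among the compounds with values here, no measured compound carries piperidin-1-yl, so the group's own contribution is unknown.

With one such step, and that one inside the scatter, no shift beyond the scatter is expected in this assay. The expected step is a 1.4-fold higher number from compound 2 to compound 3 (0.14 log units; within the scatter), a slightly higher number with little confidence in the direction. For compound 3 the estimated clearance is 1200 mL/min/kg, with an expected range of 550 mL/min/kg to 2500 mL/min/kg.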

Compound 3, clearance: 1000 mL/min/kg
Compound 3: middle estimate off by 1.2-fold (0.08 log units), on the high side, within the range that was stated.
By their numbers in this assay, from the lowest: compounds 2, 3 and 1 (each within the scatter of the next).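

In this assay, piperidin-1-yl on the sulfonyl sulfur gives a 1.2-fold higher number from compound 2 to compound 3 (0.06 log units; within the scatter) against 3-(dimethylamino)pyrrolidin-1-yl, and a 1.6-fold lower number from compound 1 to compound 3 (0.21 log units; within the scatter) against 2-(hydroxymethyl)pyrrolidin-1-yl. Both steps lie within the scatter, so a third group at this position, a six-membered ring with 0 hydrogen-bond donors and 0 hydrogen-bond acceptors, still gives no separation, and the three compounds cannot be ranked on this read-out. Nothing available bears on what sets these numbers or on why the exchange at this position leaves them inside the scatter.

Still open, as far as these compounds go, is whether any group on the sulfonyl sulfur can move the number beyond the scatter; a morpholine ring, a carboxylic acid on the piperidine ring or an open-chain amine in place of the ring would each test this more sharply than another simple ring. Equally open, from the compounds shown here alone, is whether the numbers respond to changes in the shared core, since every comparison so far exchanges only the group on the sulfonyl sulfur.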